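The compounds below may be only part of what the source reports. "The series", "measured", "known", "first", "only" and "open" are said of these compounds alone.

Two quinones have so far been measured in a functional assay on A2780 cells (Homo sapiens) for inhibition, read by sulforhodamine B assay, with a stated time of 72 h; a lower number here means a stronger inhibitor, a higher number a weaker inhibitor. Compound 1 `CC1=CC(=O)C(C(C)(C)C)=CC1=O` gives 7500 nM, and compound 2 `CC(C)(C)C1=CC(=O)C=CC1=O` gives 5700 nM. Compound 2 thus holds the lower of the two numbers, yet the step of a 1.3-fold lower number from compound 1 to compound 2 (0.12 log units; within the scatter) lies within the scatter, so the two cannot truly be told apart. Compound 3 `CC(C)(C)C1=CC(=O)C(C(C)(C)C)=CC1=O` has not yet been measured. It differs from compound 2 in one place: tert-butyl in place of hydrogen on a double-bonded ring carbon. Within the data shown here, the only measured step touching this same place is a 1.3-fold lower number from compound 1 to compound 2 (0.12 log units; within the scatter), in which a methyl left that carbon without any effect beyond the scatter. A tert-butyl group entering there is a bigger alteration than a methyl leaving, but the data offer no reason to expect a shift beyond the scatter in either direction. The expected step is therefore small: a 1.1-fold higher number from compound 2 to compound 3 (0.02 log units; within the scatter). Compound 3 is estimated at 6000 nM, with a range from 2500 nM to 15000 nM.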

Compound 3, half-maximal inhibitory concentration: 34000 nM
The estimate for compound 3 lay 5.7-fold (0.75 log units) below the measured number; measured number above the stated range.
By their numbers in this assay, from the lowest: compounds 2 and 1 (each within the scatter of the next); then compound 3.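

In this assay this double-bonded ring carbon proves sensitive to what it carries: hydrogen and methyl there could not be told apart, but tert-butyl brings a 6.0-fold higher number from compound 2 to compound 3 (0.78 log units; beyond the scatter) and likewise a 4.5-fold higher number from compound 1 to compound 3 (0.66 log units; beyond the scatter). The position therefore accepts methyl as readily as hydrogen, whereas tert-butyl, with its 4 heavy atoms, leaves compound 3 as the weakest inhibitor of the three. No measurement of any other kind is available to explain this step.

The compounds shown leave open where between methyl and tert-butyl the number begins to rise, which a group such as ethyl or isopropyl at this carbon would help to show. They also leave open how an amine or a carboxylic acid at the same place would behave, since all three groups tested here are hydrogen or carbon-only groups.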